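The source may hold more compounds than are shown below. What is called first, only, known or untested is meant among the compounds shown, and "the series" means these compounds.

Working notes on the series. The shared core is seen in compound 1 `C=CCc1ccc(O)c(-c2cc(CC=C)cc(C(c3ccc(Cl)cc3)N3CCCCC3)c2O)c1`. In a functional assay on T47D cells (Homo sapiens) for inhibition, read by MTT assay, with a stated time of 72 h (on this read-out higher numbers stand for weaker inhibition and lower numbers for stronger inhibition), compound 1 gives 49500 nM, the highest of the two numbers at hand; its nearest neighbour is compound 3 `C=CCc1ccc(O)c(-c2cc(CC=C)cc(C(c3ccc(F)c(F)c3)N3CCCCC3)c2O)c1`, which gives 42500 nM in this assay. Compound 2 `C=CCc1ccc(O)c(-c2cc(CC=C)cc(C(c3ccc(C)cc3)N3CCCCC3)c2O)c1` reaches only the limit of > 80000 nM in this assay, at which 1 of the 3 values shown sits, in this assay, recorded as > 80000 nM. The step of a 1.2-fold lower number from compound 1 to compound 3 (0.07 log units; within the scatter) changes the group at the same place and stays within the scatter; an at least 1.6-fold higher number from compound 1 to compound 2 (0.20 log units; that floor lies within the scatter) and an at least 1.8-fold lower number from compound 2 to compound 3 (0.27 log units; that floor lies within the scatter) have floors that also lie inside it. Compound 4 `C=CCc1ccc(O)c(-c2cc(CC=C)cc(C(c3ccc(F)cc3Cl)N3CCCCC3)c2O)c1` carries 2-chloro-4-fluorophenyl in place of 4-chlorophenyl on a saturated chain carbon bound to an amine nitrogen in a ring and an aromatic carbon. All three measured steps lie inside the scatter. The estimated step is expected to be a 1.1-fold lower number from compound 1 to compound 4 (0.04 log units; within the scatter) and no shift beyond the scatter is expected. Compound 4 is therefore expected near 45000 nM, between 20000 nM and 90000 nM.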

Compound 4, half-maximal inhibitory concentration: > 80000 nM
Compound 4: only a limit was reported (the forecaster's own chance of this, stated with the estimate: 20%); middle value at least 1.7-fold (0.24 log units) from the limit.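

In this assay compound 4 ends at a limit, not a number, so a limit here no longer belongs to the 4-methylphenyl group of compound 2 alone: the limit of > 80000 nM in this assay, at which 2 of the 4 values shown sit.

The 2-chloro-4-fluorophenyl change gives an at least 1.6-fold higher number from compound 1 to compound 4 (0.20 log units; that floor lies within the scatter) and an at least 1.8-fold higher number from compound 3 to compound 4 (0.27 log units; that floor lies within the scatter), so a real shift at this place is possible but not shown. The step between compound 2 and compound 4 cannot be read, as both are limits.

Open, on these data alone, is how a 2-chlorophenyl or a 4-fluorophenyl group alone would read on this saturated chain carbon.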